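Shifting the Bromine of Compound 1

The source may report more compounds than this note shows. Statements on the series, on what has been measured and on what is new or still open speak of the compounds shown alone.

Compound 1 `CCCn1c(=O)[nH]c2nc(-c3ccc(S(=O)(=O)N4CCN(Cc5ccc(Br)cc5)CC4)cc3)[nH]c2c1=O` was measured in an assay on CHO cells for displacement of a labelled ligand from adenosine receptor A1 (Homo sapiens), read by scintillation counting, with a stated time of 90 min, in the presence of a further agent that is not named here; a higher number here means a weaker inhibitor, a lower number a stronger inhibitor. In this assay compound 1 gives only a limit, > 1000 nM. Two close relatives were measured beside it. Compound 2 `CCCn1c(=O)[nH]c2nc(-c3ccc(S(=O)(=O)N4CCN(c5cccc(F)c5)CC4)cc3)[nH]c2c1=O` carries 3-fluorophenyl in place of 4-bromobenzyl on an amine nitrogen in a ring, and in this assay compound 2 also gives a limit, > 1000 nM. Compound 3 `CCCn1c(=O)[nH]c2nc(-c3ccc(S(=O)(=O)N4CCN(c5ccc(Br)cc5)CC4)cc3)[nH]c2c1=O` carries 4-bromophenyl on that nitrogen, and in this assay compound 3 likewise gives a limit, > 1000 nM. The steps among them, a step that the two limits leave unreadable from compound 1 to compound 2, a step that the two limits leave unreadable from compound 1 to compound 3 and a step that the two limits leave unreadable from compound 2 to compound 3, therefore cannot be read in size or direction, since all three values rest at the limit of > 1000 nM in this assay, at which 3 of the 3 values shown sit.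

Compound 4 `CCCn1c(=O)[nH]c2nc(-c3ccc(S(=O)(=O)N4CCN(Cc5cccc(Br)c5)CC4)cc3)[nH]c2c1=O` differs from compound 1 in one place, (3-bromophenyl in place of 4-bromophenyl on a saturated chain carbon bound to an amine nitrogen in a ring). Among the measured compounds shown here, no measured step swaps 4-bromobenzyl for another benzyl group, so none bears directly on this change; what the measured set shows is only that three variations of the group on the amine nitrogen in a ring all stay at the limit. The step from compound 1 to compound 4 in this assay is therefore expected to be none beyond the scatter, and compound 4 is expected most likely to give a limit as well. The expected value for compound 4 is estimated at 3000 nM, with a range from 1000 nM to 20000 nM, an expected step that the limit leaves unreadable from compound 1 to compound 4.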

Compound 4, inhibition constant: 928 nM
Compound 4: middle estimate off by 3.2-fold (0.51 log units), on the high side; measured number outside the range, below it.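

Moving the bromine from 4-bromobenzyl to 3-bromobenzyl gives the only true number among the compounds shown in this assay, whereas the other three remain at a limit of the assay: the limit of > 1000 nM in this assay, at which 3 of the 4 values shown sit. Against those limits the change reads only as an at least 1.0-fold lower number from compound 1 to compound 4 (0.03 log units; that floor lies within the scatter), and the changes of the whole group on the amine nitrogen in a ring read as an at least 1.0-fold lower number from compound 3 to compound 4 (0.03 log units; that floor lies within the scatter) and an at least 1.0-fold lower number from compound 2 to compound 4 (0.03 log units; that floor lies within the scatter). These steps show that 3-bromobenzyl brings the value into the readable range of the assay, but not that compound 4 truly differs from its relatives by more than the scatter, and the steps among compound 1, compound 2 and compound 3 still cannot be read.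

The compounds shown leave open how far compound 1 really lies from compound 4, and whether the bromine itself matters or whether 3-chlorobenzyl, 3-methoxybenzyl or plain benzyl would give a similar value. They also leave open whether a longer chain, such as 3-bromophenethyl on the amine nitrogen in a ring, would keep a readable number in this assay.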